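The compounds below may be only part of what the source reports. "The series", "measured", "known", "first", "only" and "open" are said of these compounds alone.

Working notes on the series. In a functional assay on HepG2 cells (Mus musculus) for antiproliferative activity against HepG2 (Homo sapiens), read by MTT assay, with a stated time of 48 h (a higher number here means a weaker inhibitor, a lower number a stronger inhibitor), compound 1 `COc1cc(/C=C/c2nnc(NC(=O)c3ccc(Br)cc3)s2)c(Br)c(OC)c1OC` gives 200 nM and compound 2 `COc1cc(/C=C/c2nnc(NC(=O)c3cccc(O)c3)s2)c(Br)c(OC)c1OC` gives 220 nM. These two values lie within the scatter of each other, so no order can be read between them.

The next structure is compound 3 `COc1cc(/C=C/c2nnc(NC(=O)c3ccccc3)s2)c(Br)c(OC)c1OC`, which has hydrogen in place of hydroxy on an aromatic carbon, meta to a large group: hydrogen in place of hydroxy on an aromatic carbon. The change reads as 3-hydroxyphenyl to phenyl.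

For the measured compounds named here, only one measured step bears on it: a 1.1-fold higher number from compound 1 to compound 2 (0.04 log units; within the scatter), with 3-hydroxyphenyl in place of 4-bromophenyl on a carbonyl carbon. Going by the values given here, that step stayed within the scatter, but it is a single step, and no benzamido compound has a measured value yet. On this evidence, no change beyond the scatter is expected in this assay, in either direction. The expected step is a 1.0-fold higher number from compound 2 to compound 3 (0.02 log units; within the scatter). The estimated value for compound 3 is 230 nM, with an expected range of 100 nM to 550 nM.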

Compound 3, half-maximal inhibitory concentration: 180 nM
Compound 3: middle estimate off by 1.3-fold (0.11 log units), on the high side, and the stated range covers the measured number.
By their numbers in this assay, from the lowest: compounds 3, 1 and 2 (each within the scatter of the next).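

With the benzamido compound, the series gains an unsubstituted reference in this assay that the first two compounds did not provide. Hydrogen in place of hydroxy gives a 1.2-fold lower number from compound 2 to compound 3 (0.09 log units; within the scatter) and hydrogen in place of bromo gives a 1.1-fold lower number from compound 1 to compound 3 (0.05 log units; within the scatter) on the same ring. Each substituent can now be set against hydrogen rather than only against the other, and neither step leaves the scatter, so neither the hydroxy nor the bromo is shown to be needed for the activity seen here; no measured data bear on why these values sit so close together.

Still open, from the compounds shown here alone, is whether an amine, a carboxylic acid or a longer chain in place of that hydrogen would move the number beyond the scatter. Also open, going by these compounds, is whether hydrogen in place of hydroxy stays within the scatter on a different core.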